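The compounds below may be only part of what the source reports. "The series", "measured", "known", "first", "only" and "open" are said of these compounds alone.

Working notes on the series. Compound 1 `CO[C@@H]1O[C@H](COc2cccc(C(C)C)c2)[C@@H](O)[C@H](O)[C@H]1Oc1ccc(OC2CCCCC2)cc1` gives 41000 nM in a functional assay on A549 cells (Homo sapiens) for cytotoxicity, read by MTT assay, with a stated time of 48 h; a lower number here means that less compound is needed, a higher number that more compound is needed for the effect. Within the data shown here, compound 2 `CO[C@H]1O[C@H](COc2ccc(OC3CCCCC3)cc2)[C@@H](O)[C@H](O)[C@H]1Oc1ccc(OC2CCCCC2)cc1` gives 18000 nM in this assay, the lowest of the three numbers measured so far. Compound 3 `CO[C@H]1O[C@H](COc2ccc3c(c2)CCCC3)[C@@H](O)[C@H](O)[C@H]1Oc1cccc(C(C)C)c1` gives 40000 nM in this assay; the gap from compound 2 to compound 3 and the gap from compound 2 to compound 1 both lie beyond the usual scatter. Compound 4 `CO[C@@H]1O[C@H](COc2ccc(OC3CCCCC3)cc2)[C@@H](O)[C@H](O)[C@H]1Oc1ccc(OC2CCCCC2)cc1` is not yet measured; against compound 2 the change is the two compounds have the same atoms and bonds and differ only in configuration as drawn: 1 of 5 stereo elements differ; a stereocentre at a saturated ring carbon is drawn S in compound 2 and R in compound 4. Among the measured compounds shown here, no measured pair differs only in this way, so the step size is unanchored. A small step is expected, a 1.4-fold higher number from compound 2 to compound 4 (0.14 log units; within the scatter), with no clear direction beyond the scatter. Compound 4 is expected to give about 25000 nM, between 10000 nM and 60000 nM.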

Compound 4, half-maximal effective concentration: 25000 nM
Compound 4: middle estimate and measured number agree at the digits printed; low and high end bracket the measured number.
By their numbers in this assay, from the lowest: compounds 2, 4, 3 and 1 (each within the scatter of the next, the first and the last beyond it).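

This gives the series its first anchored step for configuration alone, a 1.4-fold higher number from compound 2 to compound 4 (0.14 log units; within the scatter) in this assay as the stereocentre at a saturated ring carbon goes from S to R. The step stays within the scatter, so this inversion at this position leaves the number unresolved from that of the parent. The comparison rests on a single variable: the fact that compounds 2 and 4 differ only in the configuration as drawn.

From the compounds shown here alone, whether inversion at the other four stereo elements stays as small remains open. So does whether an amine or a carboxylic acid on the shared core would move the number beyond the scatter.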